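The source may hold more compounds than are shown below. What is called first, only, known or untested is meant among the compounds shown, and "the series" means these compounds.

Measured so far in an ADME assay on S9 fraction from liver (Rattus norvegicus) for metabolic stability, read by LC-MS, using NADPH, with a stated time of 30 min; a higher number here means that more of the compound is left, a lower number that less of the compound is left:
Compound 1 `CCCCCCCCc1ccc(OCC(=O)Cn2ncnn2)cc1`: < 5% (a limit of the assay, not a number)
Compound 2 `CCCCCCCCc1ccc(OCC(=O)Cn2nnnc2SC)cc1`: 21%
Compound 3 `CCCCCCCCc1ccc(OCC(=O)Cn2nnnc2-c2ccccc2)cc1`: 36%

Compound 3 holds the higher of the two actual numbers, and compound 2 lies beyond the scatter under it. Compound 4 `CCCCCCCCc1ccc(OCC(=O)Cn2nnnc2-c2ccc(S(=O)(=O)N(C)C)cc2)cc1` keeps all of compound 3 and adds one group (dimethylsulfamoyl in place of hydrogen on an aromatic carbon). This is dimethylsulfamoyl in place of hydrogen on an aromatic carbon, para to a large group, so that phenyl becomes 4-(dimethylsulfamoyl)phenyl.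

Among the compounds with values here, two measured steps bear on this change, and only loosely. The closer one is a number 15 percentage points higher from compound 2 to compound 3 (beyond the scatter) with phenyl in place of methylsulfanyl on an aromatic carbon. From the compounds shown here alone, the other is a number at least 16 percentage points higher from compound 1 to compound 2 (beyond the scatter) and it starts from the limit of < 5% in this assay, at which 1 of the 3 values shown sits, so its full size stays open. Both steps go upward, but neither puts a group on the phenyl, so they set no direction for this change. With only compound 3 at 36% as an anchor, the estimate stays close to that level. The expected result is a number 2 percentage points higher from compound 3 to compound 4 (within the scatter) and no step beyond the scatter is expected in either direction. For compound 4 the estimate in this assay is 38% with an expected range from 20% to 58% overall.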

Compound 4, percent of the compound remaining: 40%
Beside the measured number, compound 4's estimate is 2 percentage points below it, and the stated range covers the measured number.
By their numbers in this assay, from the lowest: compound 2; then compounds 3 and 4 (each within the scatter of the next). At a limit, below all of these: compound 1.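

In this assay, the first group placed on the phenyl, dimethylsulfamoyl on an aromatic carbon para to a large group, gives a number 4 percentage points higher from compound 3 to compound 4 (within the scatter), so this position takes that group without a step that can be read beyond the scatter. Measured against the methylsulfanyl group, the substituted ring still gives a number 19 percentage points higher from compound 2 to compound 4 (beyond the scatter), which shows that the step seen with the plain phenyl is kept once the ring carries dimethylsulfamoyl. The values shown give no measured property that could account for either step.

With one group at this position, no trend can be drawn for the ring, and an amine or a carboxylic acid in the same place could read quite differently in this assay. It also stays open whether the same readings hold with a shorter chain in place of the long chain on the shared core, since every compound shown carries that same chain.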